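Sulfanyl in Place of Sulfonyl: Compound 4 Awaits Measurement

The compounds below may be only part of what the source reports. "The series", "measured", "known", "first", "only" and "open" are said of these compounds alone.

Compound 1 `Cc1ccc(S/C(=C/c2sccc2C)C(=O)c2ccc(Br)cc2)cc1`: in a functional assay on DU-145 cells (Homo sapiens) for inhibition, read by trypan blue exclusion, with a stated time of 96 h (on this read-out lower numbers stand for stronger inhibition of growth and higher numbers for weaker inhibition of growth), compound 1 gives 50000 nM.
Compound 2 `Cc1ccc(S/C(=C/c2ccc(N(C)C)cc2)C(=O)c2ccc(Cl)cc2)cc1`: in this assay compound 2 reaches only a limit of the assay, > 100000 nM.
Compound 3 `Cc1ccc(S(=O)(=O)/C(=C/c2ccc(N(C)C)cc2)C(=O)c2ccc(Br)cc2)cc1`: in this assay compound 3 gives 50000 nM.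

Compound 3 stands level with compound 1 at the digits shown, within the scatter; the remaining value in the set is a limit (the limit of > 100000 nM in this assay, at which 1 of the 3 values shown sits). Compound 4 `Cc1ccc(S/C(=C/c2ccc(N(C)C)cc2)C(=O)c2ccc(Br)cc2)cc1` has not yet been measured. It differs from compound 3 by (4-methylphenyl)sulfanyl in place of (4-methylphenyl)sulfonyl on a double-bonded chain carbon bound to a carbonyl carbon and a double-bonded chain carbon. Going by the values given here, no step between measured compounds is available, so the limit seen for compound 2 is the nearest guide. The step in this assay from compound 3 to compound 4 is expected to run toward weaker inhibition, likely beyond the scatter, at a 2.0-fold higher number from compound 3 to compound 4 (0.30 log units; within the scatter). Compound 4 is therefore estimated at 100000 nM, between 40000 nM and 250000 nM.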

Compound 4, concentration for 50% growth inhibition: > 100000 nM
Compound 4: no number, only a limit; the forecaster's own chance of this, stated with the estimate: 50%; the middle value sits exactly at the limit.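

In this assay, (4-methylphenyl)sulfanyl in place of (4-methylphenyl)sulfonyl gives an at least 2.0-fold higher number from compound 3 to compound 4 (0.30 log units; that floor lies within the scatter), so this change at this position can be read only as a floor, not as a size. With 4-(dimethylamino)phenyl in place of 3-methylthiophen-2-yl, the result is an at least 2.0-fold higher number from compound 1 to compound 4 (0.30 log units; that floor lies within the scatter), again only a floor. The step that joins two limits of the assay cannot be read: the limit of > 100000 nM in this assay, at which 2 of the 4 values shown sit.

The compounds shown leave open how a (4-methylphenyl)sulfinyl or a methylsulfonyl group would read at this position. They also leave open how far above its limit compound 4 truly lies.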